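Adding a second methoxy to compound 1: expectation

The compounds below may be only part of what the source reports. "The series", "measured", "known", "first", "only" and "open" are said of these compounds alone.

Compound 1 `COc1cccc(/C(=C\c2cn(C(C)=O)c3ccc(OCc4ccccc4)cc23)C(=O)O)c1` was tested in a functional assay on KB cells (Homo sapiens) for cytotoxicity, read by MTT assay, with a stated time of 72 h; a lower number here means a stronger inhibitor, a higher number a weaker inhibitor. In this assay compound 1 gives only a limit, > 100000 nM, and not a number. Compound 2 `COc1ccc(OC)c(/C(=C\c2cn(C(C)=O)c3ccc(OCc4ccccc4)cc23)C(=O)O)c1` carries a methoxy in place of hydrogen on an aromatic carbon of the same core. In this assay compound 2 likewise gives only a limit, > 100000 nM. The step that the two limits leave unreadable from compound 1 to compound 2 therefore cannot be read, because the limit of > 100000 nM in this assay, at which 2 of the 2 values shown sit, holds both values at the edge of what the assay reports.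

Compound 3 `COc1cc(OC)cc(/C(=C\c2cn(C(C)=O)c3ccc(OCc4ccccc4)cc23)C(=O)O)c1` has not yet been measured. It differs from compound 1 by methoxy in place of hydrogen on an aromatic carbon; cut one bond further out, the change reads 3-methoxyphenyl to 3,5-dimethoxyphenyl. Among the compounds with values here, the only comparison that bears on this change is the one from compound 1 to compound 2, and it has no readable size. Nothing here points to a gain in potency from an added methoxy, so compound 3 is expected to sit where compound 1 sits, with the step that the limit leaves unreadable from compound 1 to compound 3 expected to be nothing beyond the scatter. Compound 3 is estimated at 150000 nM, within 40000 nM to 600000 nM, most likely reported again only as a limit.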

Compound 3, half-maximal inhibitory concentration: 30400 nM
Compound 3: the middle estimate sits 4.9-fold (0.69 log units) above what was measured; measured number below the stated range.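

In this assay, the change from 3-methoxyphenyl to 3,5-dimethoxyphenyl gives an at least 3.2-fold lower number from compound 1 to compound 3 (0.51 log units; beyond the scatter), so compound 3 is the first of these compounds with a measured number rather than a limit. The placing of the two methoxy groups also makes a difference, which compound 1 and compound 2 alone could not show: moving from the 2,5-dimethoxyphenyl to the 3,5-dimethoxyphenyl pattern gives an at least 3.2-fold lower number from compound 2 to compound 3 (0.51 log units; beyond the scatter), so having two methoxy groups on this ring is not enough on its own to bring a measured number. Both sizes are only minimum sizes, and the step from compound 1 to compound 2 cannot be read, because these comparisons rest on limits: the limit of > 100000 nM in this assay, at which 2 of the 3 values shown sit.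

From the compounds shown here alone, how far compound 1 and compound 2 actually lie from compound 3 remains open, and with a single measured number the shift cannot be called a trend. Also open, going by these compounds, is whether the gain is specific to methoxy or would persist with a hydroxy group, a fluorine atom or a longer ethoxy group at the same place, or would grow further in a 3,4,5-trimethoxyphenyl ring.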